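Methyl for Hydrogen at Two Places in a Chemokine Receptor Series

The source may report more compounds than this note shows. Statements on the series, on what has been measured and on what is new or still open speak of the compounds shown alone.

The study compares three measured compounds and one that awaits measurement in an assay on CHO cells for displacement of a labelled ligand from C-X-C chemokine receptor type 3 (Homo sapiens), with a stated time of 60 min; a lower number here means a stronger inhibitor, a higher number a weaker inhibitor. Compound 1 `Cc1cc(CN(CC2CCCC2)[C@@H](CC(=O)O)c2ccc(Cl)cc2)ccc1OCCN1C(=O)CCC1=O` gives 36 nM in this assay, the lowest of the three numbers. Compound 2 `Cc1cc(CN(C)C(CC(=O)O)c2ccc(Cl)cc2)ccc1OCCn1c(=O)ccn(C)c1=O` gives 1300 nM, and compound 3 `CCN(Cc1ccc(OCCn2c(=O)ccn(C)c2=O)c(C)c1)C(CC(=O)O)c1ccc(Cl)cc1` gives 428 nM. The core of compound 1 and the core of compound 2 are different, and the difference between the two cores is not broken down here; their numbers simply show compound 1 well ahead of both.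

Compound 2 and compound 3 differ in one place: methyl in place of hydrogen on a saturated chain carbon bound to an amine nitrogen. This change brought a 3.0-fold lower number from compound 2 to compound 3 (0.48 log units; beyond the scatter), a modest step but beyond the usual scatter.

Compound 4 `CCc1cc(CN(CC2CCCC2)[C@@H](CC(=O)O)c2ccc(Cl)cc2)ccc1OCCN1C(=O)CCC1=O` stands to compound 1 in a related way: methyl in place of hydrogen on a saturated chain carbon bound to an aromatic carbon. It is the same kind of change, methyl in place of hydrogen, cut one bond further out reading as methyl to ethyl, but not the same change, since in compound 3 the methyl enters on a saturated chain carbon bound to an amine nitrogen, whereas in compound 4 it enters on a saturated chain carbon bound to an aromatic carbon. Within the data shown here, because the only precedent is the step of a 3.0-fold lower number from compound 2 to compound 3 (0.48 log units; beyond the scatter), which sits at a different place and on a different core, the account expects a smaller step from compound 1 to compound 4 in this assay, estimated as a 1.3-fold lower number from compound 1 to compound 4 (0.11 log units; within the scatter), near the scatter. Compound 4 is accordingly estimated at 28 nM, with a range from 10 nM to 80 nM.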

Compound 4, half-maximal inhibitory concentration in the C-X-C chemokine receptor type 3 assay: 31 nM
For compound 4 the middle estimate is 1.1-fold (0.04 log units) below the measured one; low and high end bracket the measured number.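

In the C-X-C chemokine receptor type 3 assay compound 1 gives 36 nM and compound 4 gives 31 nM, and methyl in place of hydrogen on a saturated chain carbon bound to an aromatic carbon gives a 1.2-fold lower number from compound 1 to compound 4 (0.06 log units; within the scatter), so on the core of compound 1 this change leaves the reading within the usual scatter. Set beside the earlier step, the new one cannot be told apart from it, even though only the earlier step lies beyond the scatter on its own: the same change on two cores in the C-X-C chemokine receptor type 3 assay, a 3.0-fold lower number (0.48 log units; beyond the scatter) from compound 2 to compound 3 and a 1.2-fold lower number (0.06 log units; within the scatter) from compound 1 to compound 4, 2.6-fold (0.42 log units) apart, within the scatter of two such steps. This shows that the two results are compatible across the two cores, but it does not show that the change carries over reliably, since each core supplies a single pair and the methyl enters at a different place in each, on a carbon bound to an amine nitrogen in compound 3 and on a carbon bound to an aromatic carbon in compound 4.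

In a physicochemical assay for solubility, at pH 1.1 (a higher number here means a more soluble compound, a lower number a less soluble compound), compound 1 gives 3000000 nM and compound 4 gives 3000000 nM; the same pair gives no change at the digits printed from compound 1 to compound 4 (within the scatter), and the compounds shown leave open whether that would hold for a longer chain, such as propyl, or for an amine or a carboxylic acid at this place. They also leave open how methyl in place of hydrogen at this same place would read on the core of compound 2, where a direct comparison of the two cores could be made.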